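The source may report more compounds than this note shows. Statements on the series, on what has been measured and on what is new or still open speak of the compounds shown alone.

Working notes on the sulfonyl-linked series.

Two compounds carry numbers in an ADME assay on the whole organism (strain Han-Wistar) for pharmacokinetics, with Rattus norvegicus as the target, read by LC-MS, at a dose of 2 mg/kg by the oral route; on this read-out higher numbers stand for higher exposure at the dose given and lower numbers for lower exposure. Compound 1 `CN1CCN(CCCS(=O)(=O)c2ccc3nc(NC(=O)NC(=O)c4cccc(-n5cccn5)c4Cl)sc3c2)CC1` gives 12 nM in this assay. Compound 2 `CCN(CC)CCCS(=O)(=O)c1ccc2nc(NC(=O)NC(=O)c3cc(-n4cccn4)ccc3Cl)sc2c1` gives 1600 nM in this assay, the highest of the two values recorded, and the gap between compound 2 and compound 1 is far beyond the usual scatter. The two differ in more than one place, so nothing is drawn from that pair as a single step.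

Compound 3 `CN1CCN(CCCS(=O)(=O)c2ccc3nc(NC(=O)NC(=O)c4cc(-n5cccn5)ccc4Cl)sc3c2)CC1` is not yet measured. Set against compound 2 it shows (4-methylpiperazin-1-yl in place of diethylamino on a saturated chain carbon, three bonds along the chain from a sulfonyl sulfur). Within the data shown here, no measured pair isolates this change. Among the measured compounds shown here, the only hint is that compound 1, which carries the same 4-methylpiperazin-1-yl group, sits at 12 nM, while compound 2 with diethylamino sits at 1600 nM; the second difference between those two leaves the attribution open.

On that basis a fall in exposure is expected from compound 2 to compound 3, a 5.3-fold lower number from compound 2 to compound 3 (0.73 log units; beyond the scatter), beyond the scatter but held with little confidence. Compound 3 is estimated at 300 nM, within a range from 40 nM to 2000 nM.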

Compound 3, maximal plasma concentration: 1200 nM
For compound 3 the middle estimate is 4.0-fold (0.60 log units) below the measured one, and the stated range covers the measured number.
By their numbers in this assay, from the lowest: compound 1; then compounds 3 and 2 (each within the scatter of the next).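

In this assay, the change to 4-methylpiperazin-1-yl in place of diethylamino on a saturated chain carbon, three bonds along the chain from a sulfonyl sulfur, gives a 1.3-fold lower number from compound 2 to compound 3 (0.12 log units; within the scatter) and so does not separate from the scatter with the 2-chloro-5-(1H-pyrazol-1-yl)phenyl group in place. The large change now sits at the other place: 2-chloro-5-(1H-pyrazol-1-yl)phenyl in place of 2-chloro-3-(1H-pyrazol-1-yl)phenyl on a carbonyl carbon gives a 100-fold higher number from compound 1 to compound 3 (2.00 log units; beyond the scatter) with the 4-methylpiperazin-1-yl chain held constant. Nothing to hand accounts for either step.

Still open is whether diethylamino and 4-methylpiperazin-1-yl would also stay within the scatter of each other with 2-chloro-3-(1H-pyrazol-1-yl)phenyl on the carbonyl carbon, since the compounds shown test that exchange only with the 2-chloro-5-(1H-pyrazol-1-yl)phenyl group. Also open, on these data alone, is how far this tolerance extends on the chain, for example to morpholin-4-yl, a carboxylic acid or a longer chain between the sulfonyl sulfur and the amine.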